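From a difluorophenyl to a hydroxyphenyl ring

The source may report more compounds than this note shows. Statements on the series, on what has been measured and on what is new or still open speak of the compounds shown alone.

In an ADME assay on the whole organism (Mus musculus, strain Swiss Webster) for pharmacokinetics, read by LC-MS, at a dose of 50 mg/kg by the oral route (on this read-out lower numbers stand for lower exposure and higher numbers for higher exposure at the dose given), compound 2 (`O=C(Nc1ccc(F)c(-c2nc3ncc(-c4cccc(F)c4F)cc3[nH]2)c1)N1CCCC1`) gives 4750 ng.h/mL. Among the measured compounds shown here, compound 1 (`O=C(Nc1ccc(F)c(-c2nc3ncc(-c4cc(F)ccc4F)cc3[nH]2)c1)N1CCCC1`) gives 5620 ng.h/mL, and these two sit together at the low end of the three numbers so far. Compound 3 (`Cc1nc(C)c(C(=O)Nc2ccc(F)c(-c3nc4ncc(-c5ccccc5Cl)cn4n3)c2)o1`) gives 309000 ng.h/mL, far higher, but its structure differs in more than one place, so it offers little guidance here.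

Compound 4 (`O=C(Nc1ccc(F)c(-c2nc3ncc(-c4ccc(O)cc4)cc3[nH]2)c1)N1CCCC1`) comes from compound 2 by a single change: 4-hydroxyphenyl in place of 2,3-difluorophenyl on an aromatic carbon. In words, 4-hydroxyphenyl stands in place of 2,3-difluorophenyl on an aromatic carbon of the shared core.

For the measured compounds named here, the one measured step that bears on this is a 1.2-fold lower number from compound 1 to compound 2 (0.07 log units; within the scatter), which only rearranges the fluorines on this ring. The new change replaces the whole substituent, so that step guides the estimate only loosely, and the range must stay wide. A modest fall in this assay is expected, an estimated 2.4-fold lower number from compound 2 to compound 4 (0.38 log units; beyond the scatter). Compound 4 is expected to give about 2000 ng.h/mL, within a range of 400 ng.h/mL to 8000 ng.h/mL.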

Compound 4, area under the concentration-time curve: 137 ng.h/mL
Estimate against measurement, compound 4: 15-fold (1.16 log units) above, and the stated range ends above it.
By their numbers in this assay, from the lowest: compound 4; then compounds 2 and 1 (each within the scatter of the next); then compound 3.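

In this assay this position turns out to matter a great deal: rearranging the fluorines had left the number within the scatter, yet there is a 35-fold lower number from compound 2 to compound 4 (1.54 log units; beyond the scatter) and a 41-fold lower number from compound 1 to compound 4 (1.61 log units; beyond the scatter) when 4-hydroxyphenyl replaces the whole difluorophenyl substituent. The large fall appears from either difluorophenyl starting point, so it does not depend on which of the two fluorine arrangements is replaced. Nothing measured here accounts for the fall in exposure.

This single change removes both fluorines and brings in a hydroxyl group, so the compounds shown cannot separate the effect of losing the fluorines from that of gaining the hydroxyl. A plain phenyl ring and a 4-methoxyphenyl ring at the same position would help to pull those two parts apart.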